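Aryl triazoles with a trimethoxyphenyl group: notes on the series

The source may hold more compounds than are shown below. What is called first, only, known or untested is meant among the compounds shown, and "the series" means these compounds.

The three measured compounds share a core carrying a trimethoxyphenyl group and a second aryl group. Compound 1 `COc1ccccc1-c1ncnn1-c1cc(OC)c(OC)c(OC)c1` carries a 2-methoxyphenyl group on a ring carbon. In a functional assay on HeLa cells (Homo sapiens) for antiproliferative activity, read by MTT assay, with a stated time of 72 h (a lower number here means a stronger inhibitor, a higher number a weaker inhibitor), compound 1 gives only a limit, > 10000 nM. Compound 3 `COc1cc(-n2ncnc2-c2cccc(Cl)c2)cc(OC)c1OC` carries a 3-chlorophenyl group on a ring carbon in place of the 2-methoxyphenyl group. In this assay compound 3 likewise gives only a limit, > 10000 nM. The step that the two limits leave unreadable from compound 1 to compound 3 therefore cannot be read. Compound 2 `COc1cc(-c2ncnn2-c2ccc(Cl)cc2Cl)cc(OC)c1OC` carries a 2,4-dichlorophenyl group on a ring nitrogen. In this assay compound 2 stands at a limit, > 10000 nM; it is one of the three values, all of which sit at the same limit, as noted in the limit of > 10000 nM in this assay, at which 3 of the 3 values shown sit.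

Compound 4 `COc1cc(-c2ncnn2-c2cccc(F)c2)cc(OC)c1OC` differs from compound 2 by 3-fluorophenyl in place of 2,4-dichlorophenyl on an aromatic nitrogen. Among the measured compounds shown here, no measured step follows a change on the ring nitrogen, and the one step that is measured, from a 2-methoxyphenyl to a 3-chlorophenyl group, sits at the limit on both ends, so no size or direction can be drawn from it. Given that every value in the series stands at the limit, compound 4 is expected to stay near it, with the estimated step of a number no higher from compound 2 to compound 4 (the limit leaves the size open). For compound 4 the estimate in this assay is 10000 nM, between 3000 nM and 30000 nM, most likely again reported only as a limit.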

Compound 4, half-maximal inhibitory concentration: > 10000 nM
Compound 4: only a limit was reported (the forecaster's own chance of this, stated with the estimate: 75%); the middle value sits exactly at the limit.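

No step can be read between compound 2 and compound 4, as both stand only at a limit in this assay: the limit of > 10000 nM in this assay, at which 4 of the 4 values shown sit.

The compounds shown leave open whether any aryl group on the shared core gives a measurable value in this assay, and how the four aryl groups would rank against one another.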